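The compounds below may be only part of what the source reports. "The series", "measured", "known", "first", "only" and "open" are said of these compounds alone.

Working notes on the sulfonate series. Compound 1 `Cc1ccc(OS(=O)(=O)c2ccc(N3CCN(C)C3=O)cc2)c(C)c1` gives 2500 nM in a functional assay on MCF7 cells (Homo sapiens) for antiproliferative activity, read by sulforhodamine B assay, with a stated time of 48 h (on this read-out higher numbers stand for weaker inhibition and lower numbers for stronger inhibition), the highest number of the two values in hand. Going by the values given here, the only other measured member, compound 2 `COc1cc(OS(=O)(=O)c2ccc(N3CCN(C)C3=O)cc2)cc(OC)c1OC`, gives 120 nM in this assay, a gap that lies beyond the usual scatter; no single-change step connects the two, so what they show is taken at face value.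

Compound 3 `COc1ccc(OS(=O)(=O)c2ccc(N3CCN(C)C3=O)cc2)cc1` remains to be measured in this assay. The change from compound 1 is 4-methoxyphenyl in place of 2,4-dimethylphenyl on an oxygen, the new group keeping the same ring and heavy-atom count while bringing one hydrogen-bond acceptor.

Expectation: with compound 2 at 120 nM as the only other point of reference, the step of a 2.5-fold lower number from compound 1 to compound 3 (0.40 log units; beyond the scatter) is expected to bring a moderately lower number, of modest size and uncertain against the scatter. Compound 3 is estimated at 1000 nM, within a range of 300 nM to 4000 nM.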

Compound 3, half-maximal inhibitory concentration: 95000 nM
The estimate for compound 3 lay 95-fold (1.98 log units) below the measured number; measured number above the stated range.
By their numbers in this assay, from the lowest: compound 2; then compound 1; then compound 3.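

Going by these compounds alone, on the oxygen whose other neighbour is the sulfonyl sulfur, this assay responds strongly to a swap that keeps the ring and the heavy-atom count unchanged: 4-methoxyphenyl in place of 2,4-dimethylphenyl gives a 38-fold higher number from compound 1 to compound 3 (1.58 log units; beyond the scatter) as the first single-change step. In this one step, the added hydrogen-bond acceptor comes with a higher number, not the lower one that a gain at this place would have given. Nothing measured here accounts for the size of the step.

The compounds shown do not separate the loss of the two methyl groups from the arrival of the methoxy group, so it remains open which part of the swap carries the step. Also open, from the compounds shown here alone, is how an unsubstituted phenyl, a 4-methylphenyl or a 4-chlorophenyl group would read on the same oxygen.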